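A few compounds are considered here, and "the series" means these few. Any claim that something is new, unique, unknown or untested is made for them only; others in the source may bear on it.

Working notes on a short series of four compounds. Compound 1 `CC(Sc1nnc(-c2ccncc2)s1)C(=O)Nc1ccc(Cl)cc1Cl`, compound 2 `O=C(CCSc1nnc(-c2ccncc2)s1)NCc1ccccc1Cl` and compound 3 `CC(CSc1nnc(-c2ccncc2)s1)C(=O)NCc1ccccc1Cl` share one core and differ in the chain between the sulfur and the carbonyl and in the group on the amide side. In an ADME assay on BHK-21 cells (Mesocricetus auratus) for cytotoxicity, with a stated time of 3 days (a lower number here means that less compound is tolerated, a higher number that more compound is tolerated), compound 1 gives > 50000 nM, which is a limit of the assay and not a number. In this assay compound 2 gives > 50000 nM, again a limit. In this assay compound 3 gives > 50000 nM, also a limit, so compound 3 stands at the ceiling of what was tested and has no number of its own. Among the measured compounds shown here, the one step between neighbouring measured compounds, a step that the two limits leave unreadable from compound 2 to compound 3, cannot be read because of the limit of > 50000 nM in this assay, at which 3 of the 3 values shown sit. Compound 4 `CC(CSc1nnc(-c2ccncc2)s1)C(=O)NCc1ccccc1` is reached from compound 3 by hydrogen in place of chloro on an aromatic carbon. For the measured compounds named here, no measured step touches this change; the only measured step is itself unreadable, and every value shown rests at the limit. No step beyond the scatter is therefore expected in this assay, in either direction, and the expected step is a step that the limit leaves unreadable from compound 3 to compound 4. Compound 4 is expected to give about 60000 nM, with a range from 20000 nM to 150000 nM, most probably once more only a limit.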

Compound 4, half-maximal cytotoxic concentration: > 50000 nM
Compound 4 was reported as a limit (the forecaster's own chance of this, stated with the estimate: 85%); the middle value is on the limit's open side.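

In this assay no new step can be read from compound 3 to compound 4, where 2-chlorobenzyl gives way to benzyl, because both values rest at the same limit: the limit of > 50000 nM in this assay, at which 4 of the 4 values shown sit.

The compounds shown leave open where tolerance ends for compound 1, compound 2, compound 3 and compound 4, and whether the chain or the group on the amide side changes it at all.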